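Trimming the amine chain of compound 1 down to methyl

The source may report more compounds than this note shows. Statements on the series, on what has been measured and on what is new or still open speak of the compounds shown alone.

Of the compounds shown here, three sharing one core have been tested in a functional assay on SK-OV-3 cells (Homo sapiens) for cytotoxicity, read by sulforhodamine B assay; a higher number here means a weaker inhibitor, a lower number a stronger inhibitor. Compound 1 `COCCNc1nc(-c2ccccc2)nc2ccccc12` gives 22.9 ug/mL and stands second highest of the three numbers. Compound 2 `COC(=O)CNc1nc(-c2ccccc2)nc2ccccc12` gives 35.5 ug/mL, and compound 3 `CC(C)Nc1nc(-c2ccccc2)nc2ccccc12` gives 16.9 ug/mL. The two measured steps away from compound 1 are small: a 1.6-fold higher number from compound 1 to compound 2 (0.19 log units; within the scatter), and a 1.4-fold lower number from compound 1 to compound 3 (0.13 log units; within the scatter). Among the measured compounds shown here, only the step between the other two, a 2.1-fold lower number from compound 2 to compound 3 (0.32 log units; beyond the scatter), reaches beyond the scatter, and even that is modest.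

Compound 4 `CNc1nc(-c2ccccc2)nc2ccccc12` is the next compound, not yet measured. It differs from compound 1 in one place: hydrogen in place of methoxymethyl on a saturated chain carbon bound to a nitrogen on an aromatic ring. The substituent on the ring nitrogen thus shrinks from 2-methoxyethyl to methyl. For the measured compounds named here, no measured step removes part of this chain in the same way, but the closest comparison, the exchange of 2-methoxyethyl for isopropyl from compound 1 to compound 3, stayed within the scatter, and changing the end of the chain from compound 1 to compound 2 also did. Taken together, these steps suggest that the ring-nitrogen substituent has little effect on this assay. The number for compound 4 is therefore expected to lie close to that of compound 1, with the estimated step of a 1.0-fold lower number from compound 1 to compound 4 (0.02 log units; within the scatter) within the scatter. Compound 4 is estimated at 22 ug/mL, in a range from 10 ug/mL to 45 ug/mL.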

Compound 4, half-maximal inhibitory concentration: 33.6 ug/mL
For compound 4 the middle estimate is 1.5-fold (0.18 log units) below the measured one; low and high end bracket the measured number.
By their numbers in this assay, from the lowest: compounds 3, 1, 4 and 2 (each within the scatter of the next, the first and the last beyond it).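

In this assay, cutting the chain back to methyl gives a 1.5-fold higher number from compound 1 to compound 4 (0.17 log units; within the scatter) as the result, so removing the whole methoxymethyl part does not shift the number measurably. The same holds against the other two compounds, with a 2.0-fold higher number from compound 3 to compound 4 (0.30 log units; within the scatter) as one comparison and a 1.1-fold lower number from compound 2 to compound 4 (0.02 log units; within the scatter) as the other, which places compound 4 within the scatter of all three earlier compounds. Across methyl, isopropyl, 2-methoxyethyl and (methoxycarbonyl)methyl on this nitrogen, the only gap beyond the scatter remains the modest 2.1-fold lower number from compound 2 to compound 3 (0.32 log units; beyond the scatter) and no link to chain length appears, while no measurement of any other kind bears on these numbers.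

The compounds shown leave open whether a quite different group on this nitrogen, such as a benzyl group, a longer chain ending in an amine, or a chain ending in a carboxylic acid, would move the number well beyond the scatter. They also leave open what happens with no carbon chain at all, as in the plain amino group, and whether the same flat picture would hold on a different core.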